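A few compounds are considered here, and "the series" means these few. Any claim that something is new, unique, unknown or untested is made for them only; others in the source may bear on it.

In a functional assay on HEK293 cells for agonist activity at G-protein coupled receptor 39 (Homo sapiens), read by scintillation proximity assay and inositol phosphate accumulation, with a stated time of 75 min (a lower number here means that less compound is needed, a higher number that more compound is needed for the effect), compound 1 `Cc1nn(-c2ncnc3nc[nH]c23)c2c1C(OCCc1ccccc1)CC(=O)N2` gives 40 nM. Among the numbers measured so far, compound 1 holds the lower of the two, yet the gap to its nearest neighbour is within the usual scatter, so the two compounds cannot really be told apart. That neighbour, compound 2 `CCC(C(=O)NC1CC(=O)Nc2c1c(C)nn2-c1ncnc2nc[nH]c12)c1ccccc1`, gives 79 nM in this assay. A third compound, compound 3 `Cc1cc(C)nc(-n2nc(C)c3c2NC(=O)CC3c2ccc(F)cc2F)n1`, returns > 10000 nM in this assay, which is a limit of the assay and not a number; (the limit of > 10000 nM in this assay, at which 1 of the 3 values shown sits).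

Compound 4 `Cc1cc(C)n(CCOC2CC(=O)Nc3c2c(C)nn3-c2ncnc3nc[nH]c23)n1` has not yet been measured. It differs from compound 1 in a single place: 3,5-dimethyl-1H-pyrazol-1-yl in place of phenyl on a saturated chain carbon, two bonds along the chain from an oxygen on a saturated carbon. Among the compounds with values here, no pair of measured compounds shows what such a swap does in this assay, so there is nothing to lean on beyond the structures themselves. A step from compound 1 to compound 4 of modest size is expected, likely toward a somewhat higher number but possibly not beyond the scatter, and the expected step is a 2.0-fold higher number from compound 1 to compound 4 (0.30 log units; within the scatter). On that basis compound 4 is estimated to give 80 nM in this assay, with a likely range from 25 nM to 300 nM.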

Compound 4, half-maximal effective concentration: 2000 nM
Compound 4: the middle estimate sits 25-fold (1.40 log units) below what was measured; measured number outside the range, above it.
By their numbers in this assay, from the lowest: compounds 1 and 2 (each within the scatter of the next); then compound 4. At a limit, above all of these: compound 3.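

Swapping phenyl for 3,5-dimethyl-1H-pyrazol-1-yl on the saturated chain carbon gives a 50-fold higher number from compound 1 to compound 4 (1.70 log units; beyond the scatter) in this assay, so the ring at the end of this chain strongly affects the result. Within the data shown here, the earlier compounds could not show this, as no two of them differ in only one place, and this is the first single change whose size can be read. The counts make the size of the step more striking: the entering ring has only one more heavy atom than the phenyl it replaces, but it has five ring members instead of six and brings two nitrogens and two hydrogen-bond acceptors, yet nothing measured here explains why this swap has such a large effect.

This one swap changes the ring size, the nitrogen content and the methyl groups all at once, so the compounds shown cannot separate the contribution of each. A pyridin-2-yl ring on the same chain would keep the six-membered ring while adding a nitrogen, and an unsubstituted 1H-pyrazol-1-yl group would remove the two methyl groups, so each would isolate one part of the change.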